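The source may report more compounds than this note shows. Statements on the series, on what has been measured and on what is new or still open speak of the compounds shown alone.

Compound 1 `COc1cccc(CNC(=O)c2nc(Br)c3cccnc3c2N[C@H]2CC[C@H](N)CC2)c1` stands at the start of this account, but it stands without a number: in a functional assay on MCF7 cells (Homo sapiens) for cytotoxicity, read by MTT assay, with a stated time of 72 h (a higher number here means a weaker inhibitor, a lower number a stronger inhibitor), compound 1 gives "not determined" (no result reported), so nothing places it on the potency scale. Compound 2 `O=C(NCc1ccc(F)cc1)c1nc(Br)c2cccnc2c1NCc1ccccc1` is a close relative of the same core, and in this assay compound 2 likewise gives "not determined" (no result reported). Only compound 3 `CS(=O)(=O)NCCCN(c1nc(C(=O)NCc2ccc(F)cc2)c(O)c2ncccc12)S(C)(=O)=O` has a reported result, and that result is a limit of the assay rather than a measured number: in this assay compound 3 gives > 20000 nM. Within the data shown here, the sole anchor for the whole set is therefore (the limit of > 20000 nM in this assay, at which 1 of the 3 values shown sits), which says only that the one compound with a result is a weak inhibitor, beyond what the assay can resolve.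

Compound 4 `N[C@H]1CC[C@H](Nc2c(C(=O)NCc3ccccn3)nc(Br)c3cccnc23)CC1` differs from compound 1 in a single place (pyridin-2-yl in place of 3-methoxyphenyl on a saturated chain carbon bound to an amide-type nitrogen). Compound 1 has no number in this assay. Among the measured compounds shown here, no measured step exists to lean on, and the change itself gives no direction; the expectation is a step no larger than the scatter, in either direction, from a starting point that is itself unknown. Given that the only result in the set is a limit, compound 4 is expected to be a weak inhibitor in this assay, estimated at 12000 nM, with a wide range from 2000 nM to 40000 nM, and a real chance that only a limit is reported.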

Compound 4, half-maximal inhibitory concentration: 15000 nM
Compound 4: the middle estimate sits 1.3-fold (0.10 log units) below what was measured; the measured number falls inside the stated range.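

In this assay compound 4 gives 15000 nM, but compound 1 has no number there, and no step can be read between the two compounds. Going by these compounds, what swapping 3-methoxyphenyl for pyridin-2-yl does to cytotoxicity stays open, as does whether a change elsewhere on the shared core would give a stronger inhibitor.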